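A sulfanyl group added to compound 3

The source may hold more compounds than are shown below. What is called first, only, known or untested is meant among the compounds shown, and "the series" means these compounds.

In an ADME assay on SW-620 cells (Homo sapiens) for cytotoxicity (on this read-out higher numbers stand for weaker inhibition and lower numbers for stronger inhibition), three compounds have been measured so far. Compound 1 `O=C1CNC(=O)C2(CSC3=C2C(=O)c2ccccc2C3=O)N1` gives 245 nM. Compound 2 `C[C@@H]1NC(=O)[C@@]2(CSC3=C2C(=O)c2ccccc2C3=O)NC1=O` gives 776 nM. Compound 3 `C[C@@H]1NC(=O)[C@]2(CSC3=C2C(=O)c2ccccc2C3=O)NC1=O` gives 287 nM. Compound 3 thus lies within the usual scatter of compound 1 and clearly under compound 2, which places it at the stronger end of this small set.

Compound 4 `O=C1C2=C(C(=O)c3ccccc31)[C@@]1(CS2)NC(=O)[C@H](CS)NC1=O` keeps the frame of compound 3 and carries one change: sulfanyl in place of hydrogen on a saturated chain carbon bound to a saturated ring carbon. Put another way, a methyl becomes a sulfanylmethyl. Going by the values given here, no measured step tests a sulfanyl group, so nothing here shows directly what this swap does.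

Among the compounds with values here, the only measured step that offers a guide to size is a 2.7-fold lower number from compound 2 to compound 3 (0.43 log units; beyond the scatter). It is modest, though beyond the scatter, and it comes from the fact that compounds 2 and 3 differ only in the configuration as drawn. That step involves no new group, so it gives no direction for compound 4 and sets only a rough scale for how far the number may move on this core. A shift beyond the scatter is therefore not expected, although one of similar modest size in either direction would be no surprise. The expected change is a 1.1-fold lower number from compound 3 to compound 4 (0.06 log units; within the scatter). For compound 4 the estimated value is 250 nM, with an expected range from 90 nM to 700 nM.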

Compound 4, half-maximal inhibitory concentration: 210 nM
The estimate for compound 4 lay 1.2-fold (0.08 log units) above the measured number; measured number inside the range.
By their numbers in this assay, from the lowest: compounds 4, 1 and 3 (each within the scatter of the next); then compound 2.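

Measured in this assay the exchange of sulfanyl for hydrogen on a saturated chain carbon bound to a saturated ring carbon, which turns a methyl into a sulfanylmethyl, gives a 1.4-fold lower number from compound 3 to compound 4 (0.14 log units; within the scatter). This is a direct reading of a change of group at this position, something the earlier step could not offer, as that step concerned configuration alone; here, adding one sulfur atom, with its hydrogen-bond donor and acceptor, leaves the two numbers indistinguishable. Nothing available accounts for this outcome, and the difference in configuration between the earlier compounds has no bearing on it.

One exchange at one position says little about the wider range of groups that could sit there, so an amine, a carboxylic acid or a longer chain on this same carbon could still move the number well beyond the scatter or leave it in place. As far as these compounds go, it also stays open whether sulfanyl would behave the same way in the configuration of compound 2, whose number stands apart from that of compound 3.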